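The source may report more compounds than this note shows. Statements on the series, on what has been measured and on what is new or still open speak of the compounds shown alone.

Going by the values given here, in an ADME assay on L02 cells (Homo sapiens) for antiproliferative activity, read by MTT assay, with a stated time of 48 h (on this read-out higher numbers stand for weaker inhibition and lower numbers for stronger inhibition), compound 3 `C=CCN(C)C(=O)c1ccc(C(CC)(CC)c2ccc(OCCC(O)(CC)CC)c(C)c2)n1CC` gives 1190 nM, the lowest number measured so far. Compound 2 `CCn1c(C(=O)NCCN)ccc1C(CC)(CC)c1ccc(OCCC(O)(CC)CC)c(C)c1` gives 2940 nM. Compound 1 `CCn1c(C(=O)NCC#N)ccc1C(CC)(CC)c1ccc(OCCC(O)(CC)CC)c(C)c1` reaches only a limit of the assay, > 50000 nM. Compound 4 `C#CC(C)OC(=O)c1ccc(C(CC)(CC)c2ccc(OCCC(O)(CC)CC)c(C)c2)n1CC` differs from compound 3 by (1-methylprop-2-yn-1-yl)oxy in place of allyl(methyl)amino on a carbonyl carbon. Two measured changes sit on that carbonyl carbon: an at least 42-fold lower number from compound 1 to compound 3 (1.62 log units; beyond the scatter), which is large, and a 2.5-fold lower number from compound 2 to compound 3 (0.39 log units; beyond the scatter), which is modest. Neither puts an oxygen where the nitrogen stands. With compound 3 at 1190 nM, the change is expected to raise the number in this assay by a modest to large step, a 2.5-fold higher number from compound 3 to compound 4 (0.40 log units; beyond the scatter). For compound 4 the estimated value is 3000 nM, with an expected range from 800 nM to 20000 nM.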

Compound 4, half-maximal inhibitory concentration: > 50000 nM
Compound 4 was reported as a limit; the forecaster's own chance of this, stated with the estimate: 15%; middle value at least 16-fold (1.22 log units) from the limit.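

At this carbonyl carbon, an oxygen-linked group now stands where earlier compounds carried nitrogen, and in this assay the result is an at least 42-fold higher number from compound 3 to compound 4 (1.62 log units; beyond the scatter), with an at least 17-fold higher number from compound 2 to compound 4 (1.23 log units; beyond the scatter). The value of compound 4 is a limit, the same one that compound 1 reaches: the limit of > 50000 nM in this assay, at which 2 of the 4 values shown sit. The step between these two compounds cannot be read.

The compounds shown leave open whether the oxygen or the 1-methylprop-2-yn-1-yl chain accounts for the rise. An allyl ester, or an amide bearing 1-methylprop-2-yn-1-yl on its nitrogen, would separate the two.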